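The compounds below may be only part of what the source reports. "The series", "measured", "known", "first", "only" and "open" are said of these compounds alone.

Compound 2 `COc1ccc(Oc2ccc3c(NCCCNCc4cccc(OC)c4O)ccnc3c2)cc1` gives 317 10^-6 cm/s in an ADME assay for permeability, using PAMPA, with a stated time of 30 min, at pH 7.4; a lower number here means that the compound crosses the layer more slowly, a higher number that the compound crosses the layer faster. Going by the values given here, on that number compound 2 stands level with compound 1 `COc1cccc(CNCCCNc2ccnc3cc(Oc4ccc(Cl)cc4)ccc23)c1O`, whose value in this assay is 317 10^-6 cm/s; the only step measured, no change at the digits printed from compound 1 to compound 2 (within the scatter), put a methoxy in place of a chloro on an aromatic carbon and moved nothing beyond the scatter. Compound 3 `COc1cccc(CNCCCNc2ccnc3cc(Cc4ccccc4)ccc23)c1O` has not yet been measured. It differs from compound 2 by benzyl in place of 4-methoxyphenoxy on an aromatic carbon. Among the compounds with values here, no measured step covers this kind of change: the one known step exchanged a single group for another, whereas here a whole 4-methoxyphenoxy leaves and a benzyl enters in its place. Within the data shown here, with the only known step showing no movement, and nothing in the data to say which way a larger change would go, the expected step is a 1.1-fold lower number from compound 2 to compound 3 (0.02 log units; within the scatter), within the scatter. For compound 3 the estimated value in this assay is 300 10^-6 cm/s, with a range from 150 10^-6 cm/s to 600 10^-6 cm/s.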

Compound 3, apparent permeability: 23 10^-6 cm/s
Estimate against measurement, compound 3: 13-fold (1.12 log units) above; the whole stated range lies above it.
By their numbers in this assay, from the lowest: compound 3; then compounds 1 and 2 (each within the scatter of the next).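

In this assay, replacing the whole group on this aromatic carbon has a large effect: benzyl in place of 4-methoxyphenoxy gives a 14-fold lower number from compound 2 to compound 3 (1.14 log units; beyond the scatter), and benzyl in place of 4-chlorophenoxy gives a 14-fold lower number from compound 1 to compound 3 (1.14 log units; beyond the scatter). Exchanging chloro for methoxy on the group left the number unmoved, so the group's outer substituent can vary without a visible effect in that one case, while the larger exchange cannot be made freely, even though a six-membered aromatic ring of carbon stays at this place in all three compounds. Nothing measured here explains the drop.

Benzyl differs from both phenoxy groups in more than one way, so the compounds do not show which difference carries the step. Going by these compounds, a plain phenoxy, or an amine linking the ring to this carbon, remains open.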